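A few compounds are considered here, and "the series" means these few. Any claim that something is new, unique, unknown or untested is made for them only; others in the source may bear on it.

Among the measured compounds shown here, in a functional assay on SK-OV-3 cells (Homo sapiens) for antiproliferative activity, read by MTT assay, with a stated time of 72 h (on this read-out higher numbers stand for weaker inhibition and lower numbers for stronger inhibition), compound 2 `CC(=O)c1ccc(-c2cccc(NC(=O)CCc3cccc4c3COB4O)c2)cc1` gives 57000 nM, the only actual number so far. Compound 1 `CC(=O)c1ccc(-c2cccc(NC(=O)CCc3ccc4c(c3)B(O)OC4)c2)cc1` gives > 100000 nM, which is a limit of the assay and not a number. Compound 3 `CC(=O)c1ccc(-c2cccc(NC(=O)CCc3ccccc3)c2)cc1` keeps the rest of compound 2 but carries a group of 6 heavy atoms (6 carbon; one six-membered aromatic ring of carbon only) in place of a group of 10 heavy atoms (7 carbon, 1 boron, 2 oxygen; one five-membered non-aromatic ring with 2 hetero atoms, one six-membered aromatic ring of carbon only), on a saturated chain carbon, two bonds along the chain from a carbonyl carbon. For the measured compounds named here, the one measured step that bears on this is an at least 1.7-fold lower number from compound 1 to compound 2 (0.24 log units; that floor lies within the scatter), and it exchanges two groups of the same counted make-up, so it does not show what removing such a group does. The floor of that small step lies within the scatter. With compound 2 at 57000 nM, no clear gain or loss is expected in this assay. The expected step is a 1.3-fold higher number from compound 2 to compound 3 (0.12 log units; within the scatter), which would not exceed the scatter. Compound 3 is estimated at 75000 nM, with an expected range of 30000 nM to 190000 nM.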

Compound 3, half-maximal inhibitory concentration: 3200 nM
Compound 3: middle estimate off by 23-fold (1.37 log units), on the high side; measured number below the stated range.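

Where the earlier pair only exchanged two groups of the same counted make-up, this result removes the boron-containing group at this place altogether, and in this assay phenyl there gives an 18-fold lower number from compound 2 to compound 3 (1.25 log units; beyond the scatter). The same exchange gives an at least 31-fold lower number from compound 1 to compound 3 (1.49 log units; beyond the scatter), so both boron-containing groups shown stand on the weak side of phenyl at this saturated chain carbon. That second step is only a floor, since compound 1 carries a limit of the assay and not a number: the limit of > 100000 nM in this assay, at which 1 of the 3 values shown sits.

From the compounds shown here alone, it stays open whether the boron atom or the added ring carries the difference, and a ring of carbon only in the same place would speak to that. Going by these compounds, how an amine or a carboxylic acid on the phenyl, or a longer chain, would read in this assay also stays open.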